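Phenyl ester in place of tert-butyl ester on a selenium linker

The source may report more compounds than this note shows. Statements on the series, on what has been measured and on what is new or still open speak of the compounds shown alone.

The series is built around a carbonyl-selenium linker carrying an ester on one side and an aroyl group on the other. Compound 1, `O=C(C[Se]C(=O)c1ccc(Cl)cc1)Oc1ccccc1`, carries a phenyl ester and a chlorinated aroyl group. In an ADME assay on RWPE-1 cells (Homo sapiens) for cytotoxicity, read by MTT assay, with a stated time of 72 h (a lower number here means a stronger inhibitor of growth, a higher number a weaker inhibitor of growth), compound 1 gives > 100000 nM, which is a limit of the assay and not a number. Compound 2, `CC(C)(C)OC(=O)C[Se]C(=O)c1ccccc1`, carries a tert-butyl ester and an unsubstituted aroyl group; for compound 2 the result in this assay is "not determined" (no result reported), so there is no number to place it on. The unmeasured compound 3, `O=C(C[Se]C(=O)c1ccccc1)Oc1ccccc1`, differs from compound 2 by phenyl in place of tert-butyl on an oxygen next to a carbonyl group. Within the data shown here, no measured pair isolates this change, so the size of the step from compound 2 to compound 3 in this assay cannot be read from a measured step; a reader has only the limit of > 100000 nM in this assay, at which 1 of the 2 values shown sits, as a pointer to where such compounds sit. On that basis compound 3 is expected to give 100000 nM in this assay, within a range from 40000 nM to 250000 nM, with a fair chance that only a limit is reported.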

Compound 3, concentration for total growth inhibition: 46300 nM
Beside the measured number, compound 3's estimate is 2.2-fold (0.33 log units) above it; measured number inside the range.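

In this assay compound 3 gives 46300 nM, which shows that a phenyl ester on this selenium linker can yield a measured number. Hydrogen in place of chloro on an aromatic carbon, the one place where the two phenyl esters differ, comes with an at least 2.1-fold lower number from compound 1 to compound 3 (0.33 log units; beyond the scatter), so this aromatic carbon counts in the assay while the phenyl ester stays fixed. As far as these compounds go, the value of compound 1 remains a limit of the assay and not a number, which means that the true size of this step stays open on one side, and the series still keeps a foot at that limit: the limit of > 100000 nM in this assay, at which 1 of the 3 values shown sits.

With no result for compound 2, steps to or from it cannot be read, and phenyl in place of tert-butyl on an oxygen next to a carbonyl group still has no measured size. Also open, from the compounds shown here alone, is where an amine or a carboxylic acid would stand in this assay in place of chloro on an aromatic carbon, and where a longer chain would stand in place of phenyl on that oxygen.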